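The source may hold more compounds than are shown below. What is called first, only, known or untested is meant among the compounds shown, and "the series" means these compounds.

Measured compounds:
Compound 1 `CN(c1ccnc(Nc2ccc(C#N)cc2)n1)c1c(F)cc(-c2ccc(C#N)cc2)cc1F` gives 148000 nM in an ADME assay on MT4 cells (Homo sapiens) for cytotoxicity, read by MTT assay, with a stated time of 5 days; on this read-out lower numbers stand for higher toxicity in this test and higher numbers for lower toxicity in this test.
Compound 2 `CCCN(c1ccnc(Nc2ccc(C#N)cc2)n1)c1c(F)cc(-c2ccc(C#N)cc2)cc1F` gives 212000 nM in this assay.
Compound 3 `CCC(C)CN(c1ccnc(Nc2ccc(C#N)cc2)n1)c1c(F)cc(-c2ccc(C#N)cc2)cc1F` gives only a limit of this assay, > 255000 nM, and no number.

Among the three, compound 3 stands at the top of the numbers, but its value is a limit, the one described by the limit of > 255000 nM in this assay, at which 1 of the 3 values shown sits, so its true position is not fixed. Compound 4 `N#Cc1ccc(Nc2nccc(N(c3c(F)cc(-c4ccc(C#N)cc4)cc3F)C3CCCC3)n2)cc1` carries the change cyclopentyl in place of 2-methylbutyl on a nitrogen on an aromatic ring on the shared core of compound 3. The measured steps that bear on this change all concern the alkyl group on that nitrogen: a 1.4-fold higher number from compound 1 to compound 2 (0.16 log units; within the scatter), an at least 1.7-fold higher number from compound 1 to compound 3 (0.23 log units; that floor lies within the scatter) and an at least 1.2-fold higher number from compound 2 to compound 3 (0.08 log units; that floor lies within the scatter). None of them reaches beyond the scatter, and each of them only lengthens or branches the chain; none exchanges a chain for a ring. The group that enters has the same count of heavy atoms as the group that leaves. Compound 4 is therefore expected to sit close to compound 3, with an at least 1.0-fold lower number from compound 3 to compound 4 (0.00 log units; that floor lies within the scatter) not beyond the scatter. The estimate for compound 4 in this assay is 250000 nM, within 120000 nM to 500000 nM, and a limit rather than a number is about as likely as not.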

Compound 4, half-maximal cytotoxic concentration: 232000 nM
For compound 4 the middle estimate is 1.1-fold (0.03 log units) above the measured one, and the stated range covers the measured number.
By their numbers in this assay, from the lowest: compounds 1, 2 and 4 (each within the scatter of the next). At a limit, above all of these: compound 3.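

In this assay, going by these compounds alone, cyclopentyl is the first ring on a nitrogen on an aromatic ring, and exchanging a chain for this ring gives a 1.1-fold higher number from compound 2 to compound 4 (0.04 log units; within the scatter) and a 1.6-fold higher number from compound 1 to compound 4 (0.20 log units; within the scatter), so neither the propyl nor the methyl comparison separates the ring from the chain. Against 2-methylbutyl, which has the same count of heavy atoms as cyclopentyl but no ring, the result is an at least 1.0-fold lower number from compound 3 to compound 4 (0.04 log units; that floor lies within the scatter), which gives only a floor and no exact size for the step. Compound 3 gives a limit and not a number, so the direct comparison of ring and chain of equal heavy-atom count stays unresolved: the limit of > 255000 nM in this assay, at which 1 of the 4 values shown sits.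

The compounds shown leave open whether a cyclohexyl ring or a phenyl ring at this nitrogen would also stay within the scatter of compound 4. They also leave open what a chain ending in a hydroxyl group, an amine or a carboxylic acid would give in this assay, since all the groups here consist of carbon and hydrogen only.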